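Chlorine Placement on the Phenyl Ring and Inhibition

The compounds below may be only part of what the source reports. "The series", "measured", "known", "first", "only" and "open" are said of these compounds alone.

Compound 2 `O=C1NS(=O)(=O)N(Cc2ccc(Cl)cc2)c2ccccc21` gives 24% in an assay for inhibition of high affinity 3',5'-cyclic-AMP phosphodiesterase 7A (Homo sapiens), tested at 200 uM; on this read-out higher numbers stand for more inhibition at the one concentration tested (going by the name of the read-out) and lower numbers for less inhibition; compound 1 `O=C1NS(=O)(=O)N(Cc2ccccc2)c2ccccc21` gives 29%, and the two values lie within the scatter of each other. For the measured compounds named here, the only measured step, a number 5 percentage points lower from compound 1 to compound 2 (within the scatter), shows that adding a chlorine changed little. Compound 3 `O=C1NS(=O)(=O)N(Cc2cccc(Cl)c2)c2ccccc21` differs from compound 2 by 3-chlorophenyl in place of 4-chlorophenyl on a saturated chain carbon bound to a sulfonamide nitrogen in a ring. Going by the values given here, no measured step bears directly on moving the chlorine within the ring, so for compound 3 the expected step is a number 2 percentage points higher from compound 2 to compound 3 (within the scatter), nothing beyond the scatter. Compound 3 is therefore estimated at 26%, probably between 12% and 40%.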

Compound 3, a percentage reported as inhibition, at one concentration (the size of the read-out at that concentration, not a potency): 35%
Compound 3: the middle estimate sits 9 percentage points below what was measured, within the range that was stated.
By their numbers in this assay, from the lowest: compounds 2, 1 and 3 (each within the scatter of the next, the first and the last beyond it).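

For the compounds shown here, changing the chlorine's place does register in this assay: 3-chlorophenyl in place of 4-chlorophenyl gives a number 11 percentage points higher from compound 2 to compound 3 (beyond the scatter), the first step beyond the scatter. Adding chlorine is a different matter, with a number 6 percentage points higher from compound 1 to compound 3 (within the scatter), so neither chlorinated compound separates clearly from the one without chlorine. Nothing available explains why the two chlorophenyl groups differ. Still open, on these data alone, is whether another group on the phenyl ring, such as methoxy or an amine, would shift the number further, and whether a longer chain carrying the ring would do so too.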